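The source may hold more compounds than are shown below. What is called first, only, known or untested is meant among the compounds shown, and "the series" means these compounds.

Compound 2, `Cn1c(Cc2ccccc2C(F)(F)F)nc(C(=O)NCc2ccccc2)c(O)c1=O`, is compared in an ADME assay on HepG2 cells (Homo sapiens) for cytotoxicity, in the presence of a further agent that is not named here (on this read-out lower numbers stand for stronger inhibition and higher numbers for weaker inhibition), with three relatives. Compound 2 reaches only the limit of > 100000 nM. Compound 1, `Cn1c(Cc2ccccc2C(F)(F)F)nc(C(=O)CCc2ccccc2)c(O)c1=O`, likewise gives the limit of > 100000 nM. Compound 3, `CC(NC(=O)c1nc(Cc2ccccc2C(F)(F)F)n(C)c(=O)c1O)c1ccccc1`, also sits at the limit of > 100000 nM. The steps a step that the two limits leave unreadable from compound 1 to compound 2, a step that the two limits leave unreadable from compound 1 to compound 3 and a step that the two limits leave unreadable from compound 2 to compound 3 therefore cannot be read in size, because of the limit of > 100000 nM in this assay, at which 3 of the 3 values shown sit. Compound 4, `CCn1c(Cc2ccccc2C(F)(F)F)nc(C(=O)NCc2ccccc2)c(O)c1=O`, carries methyl in place of hydrogen on a saturated chain carbon bound to an aromatic nitrogen. For compound 4 the change is small, methyl to ethyl, and the unreadable steps give no hint of movement, so no step beyond the scatter is expected, a step that the limit leaves unreadable from compound 2 to compound 4. Compound 4 is therefore estimated at 150000 nM, within 50000 nM to 500000 nM, and most likely once more only a limit.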

Compound 4, half-maximal inhibitory concentration: > 100000 nM
Compound 4: no number, only a limit; the forecaster's own chance of this, stated with the estimate: 85%; the middle value does not contradict the limit.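

The step from compound 2 to compound 4 cannot be read in size, because compound 4, like compound 2, gives only a limit: the limit of > 100000 nM in this assay, at which 4 of the 4 values shown sit. The compounds shown leave open whether any of these changes shifts the read-out at all.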